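Moving the Methyl Around the Pyridine Ring

The source may hold more compounds than are shown below. What is called first, only, known or untested is meant among the compounds shown, and "the series" means these compounds.

Compound 2 `Cc1ccc([C@@H](C)Oc2cc3oc(=O)n(CCC(=O)O)c3cc2Cl)nc1` is the only one of the two measured compounds that gives a proper number in a physicochemical assay for permeability, using PAMPA; a lower number here means that the compound crosses the layer more slowly, a higher number that the compound crosses the layer faster; compound 2 reaches 22 nm/s. Compound 1 `Cc1ccnc([C@@H](C)Oc2cc3oc(=O)n(CCC(=O)O)c3cc2Cl)c1` sits at a limit of the assay in this assay, reported as < 3 nm/s. For the measured compounds named here, the step of an at least 7.3-fold higher number from compound 1 to compound 2 (0.86 log units; beyond the scatter) is the single measured comparison that bears on the change at hand, and it reads against (the limit of < 3 nm/s in this assay, at which 1 of the 2 values shown sits). Compound 3 `Cc1cccc([C@@H](C)Oc2cc3oc(=O)n(CCC(=O)O)c3cc2Cl)n1` differs from compound 2 by 6-methylpyridin-2-yl in place of 5-methylpyridin-2-yl on a saturated chain carbon bound to an oxygen on an aromatic ring and a saturated chain carbon. Since that measured step and this change both shift only where the methyl sits on the pyridine, and an at least 7.3-fold higher number from compound 1 to compound 2 (0.86 log units; beyond the scatter) was large, a step beyond the scatter is plausible here as well, although its direction is not fixed by the two numbers available. The value for compound 3 in this assay is estimated at 40 nm/s, between 15 nm/s and 120 nm/s, which means an expected step of a 1.8-fold higher number from compound 2 to compound 3 (0.26 log units; within the scatter).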

Compound 3, apparent permeability: 21 nm/s
For compound 3 the middle estimate is 1.9-fold (0.28 log units) above the measured one; the measured number falls inside the stated range.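

In this assay, exchanging 5-methylpyridin-2-yl for 6-methylpyridin-2-yl gives a 1.0-fold lower number from compound 2 to compound 3 (0.02 log units; within the scatter), so the two groups cannot be told apart here, and not every shift of the methyl around the pyridine carries a large effect. For the compounds shown here, exchanging 4-methylpyridin-2-yl for 6-methylpyridin-2-yl gives an at least 7.0-fold higher number from compound 1 to compound 3 (0.84 log units; beyond the scatter), which leaves 4-methylpyridin-2-yl as the one group of the three that stands apart. Compound 1 is reported only at a limit of the assay, so that gap has no upper end: the limit of < 3 nm/s in this assay, at which 1 of the 3 values shown sits.

As far as these compounds go, how far compound 1 really lies from the other two therefore remains open. From the compounds shown here alone, it is also open whether a pyridine without the methyl, a phenyl ring, or an ethyl in place of the methyl would read like compound 2 and compound 3 or like compound 1 in this assay.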